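A few compounds are considered here, and "the series" means these few. Any claim that something is new, unique, unknown or untested is made for them only; others in the source may bear on it.

Measured so far in a functional assay on DLD-1 cells (Homo sapiens) for antiproliferative activity, read by CellTiter-Glo, with a stated time of 72 h; on this read-out lower numbers stand for stronger inhibition and higher numbers for weaker inhibition:
compound 1 `Cc1ccc(-c2cccc(S(=O)(=O)N3CCC(N4CCC(C)CC4)CC3)c2)cc1` gives 11 nM
compound 2 `Cc1cccc(S(=O)(=O)N2CCC(N3CCC(C)CC3)CC2)c1` gives 25 nM

Among the measured compounds shown here, compound 2 stands at the higher of the two numbers; the single measured step, a 2.3-fold higher number from compound 1 to compound 2 (0.36 log units; beyond the scatter), puts methyl in place of 4-methylphenyl. Compound 3 `CC1CCN(C2CCN(S(=O)(=O)c3cccc(Cl)c3)CC2)CC1` differs from compound 2 by chloro in place of methyl on an aromatic carbon. For the measured compounds named here, no measured step concerns chloro in place of methyl, and the one step available changes a different group, so it offers no direct guide. With nothing to suggest a shift, compound 3 is expected to sit near compound 2, a step of no change at the digits printed from compound 2 to compound 3 (within the scatter) within the scatter. The estimate for compound 3 is 25 nM, in the range 10 nM to 60 nM.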

Compound 3, half-maximal inhibitory concentration: > 5000 nM
Compound 3 ended at the assay's limit; the forecaster's own chance of this, stated with the estimate: 2%; middle value at least 200-fold (2.30 log units) away from the limit.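

In this assay, the aromatic carbon meta to a large group proved far less forgiving than the first two compounds suggested: methyl and 4-methylphenyl differ by only a 2.3-fold higher number from compound 1 to compound 2 (0.36 log units; beyond the scatter), yet chloro in place of methyl brings an at least 200-fold higher number from compound 2 to compound 3 (2.30 log units; beyond the scatter). Chloro in place of 4-methylphenyl likewise brings an at least 450-fold higher number from compound 1 to compound 3 (2.65 log units; beyond the scatter), so a single-atom exchange here outweighs the loss of a whole ring. The reading for compound 3 is a limit and not a number: the limit of > 5000 nM in this assay, at which 1 of the 3 values shown sits.

The compounds shown leave open whether the drop is specific to chloro or extends to other groups on this carbon. Fluoro, methoxy or an amine there would test this.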